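Adding a bromo group to compound 3: cytotoxicity expectation

A few compounds are considered here, and "the series" means these few. Any claim that something is new, unique, unknown or untested is made for them only; others in the source may bear on it.

Measured compounds:
- compound 1, `COc1ccc(-c2cc3ccc(OCCCCn4cc(CNC(=O)CCCCC5CCSS5)nn4)cc3oc2=O)cc1`: 52.3%
- compound 2, `CC(=O)c1cc2ccc(OCCCCCn3cc(CNC(=O)CCCCC4CCSS4)nn3)cc2oc1=O`: 20.7%
- compound 3, `O=C(CCCCC1CCSS1)NCc1cn(CCCCCOc2ccc3cc(-c4ccccc4)c(=O)oc3c2)nn1`: 20.7%

In a functional assay on PC-12 cells (Rattus norvegicus) for cytotoxicity, read by MTT assay, with stated times of 3 h and 2 h, tested at 20 uM (a lower number here means a weaker effect, a higher number a stronger effect of the compound at the concentration tested), compound 1 gives 52.3%, the highest of the three numbers. Compound 2 gives 20.7% and compound 3 gives 20.7%; these two are level at the digits shown and together the lowest of the three. Among the compounds with values here, the only one-place step among them, no change at the digits printed from compound 2 to compound 3 (within the scatter), replaced acetyl with phenyl and left the read-out where it was, within the scatter.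

Compound 4, `O=C(CCCCC1CCSS1)NCc1cn(CCCCCOc2ccc3cc(-c4ccc(Br)cc4)c(=O)oc3c2)nn1`, has not been measured. It differs from compound 3 by bromo in place of hydrogen on an aromatic carbon. Within the data shown here, no measured step involves adding a bromo group, so nothing observed speaks directly to this change; the one step that exists, on the same part of the shared core, brought no change beyond the scatter. The step from compound 3 to compound 4 is therefore expected to be small, a number 3.3 percentage points higher from compound 3 to compound 4 (within the scatter), with no clear direction. Compound 4 is estimated at 24%, with a range from 10% to 40%.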

Compound 4, a percentage reported as activity, at one concentration (the size of the read-out at that concentration, not a potency): 52.3%
Compound 4: middle estimate off by 28.3 percentage points, on the low side, outside the stated range (above it).
By their numbers in this assay, from the lowest: compounds 2 and 3 (each within the scatter of the next); then compounds 1 and 4 (each within the scatter of the next).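

On the phenyl group of the shared core, a single added bromo matters a great deal: going from phenyl to 4-bromophenyl in this assay gives a number 31.6 percentage points higher from compound 3 to compound 4 (beyond the scatter) in this read-out. The earlier step at this same place, no change at the digits printed from compound 2 to compound 3 (within the scatter) with phenyl in place of acetyl, had suggested that the read-out did not respond to changes there, and this result shows that it can. Replacing acetyl with 4-bromophenyl gives a number 31.6 percentage points higher from compound 2 to compound 4 (beyond the scatter) and so differs from the phenyl step only by the bromo, which makes one heavy atom enough to move the number well beyond the scatter.

No measurement shown here explains why the bromo has this effect. Whether it is specific to bromo stays open, since neither chloro nor an amine on that carbon appears among these compounds.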